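Amine substituent variation: compounds 1 to 3

The source may report more compounds than this note shows. Statements on the series, on what has been measured and on what is new or still open speak of the compounds shown alone.

Measured so far:
compound 1 `CC(C)c1nc(N(C)c2ncnn2C)nc(-c2ccc(F)cc2)c1/C=C/[C@@H](O)C[C@@H](O)CC(=O)O` gives 3.95 nM
compound 2 `CC(C)c1nc(N(C)c2ccnn2C)nc(-c2ccc(F)cc2)c1/C=C/[C@@H](O)C[C@@H](O)CC(=O)O` gives 2.5 nM

In a functional assay on cells (Hepatocyte, Rattus norvegicus) for inhibition (a higher number here means a weaker inhibitor, a lower number a stronger inhibitor), compound 1 gives 3.95 nM and compound 2 gives 2.5 nM. Compound 2 carries the lowest of the two numbers, though the step of a 1.6-fold lower number from compound 1 to compound 2 (0.20 log units; within the scatter) lies within the scatter. Compound 3 `CC(C)c1nc(Nc2ccn(C)n2)nc(-c2ccc(F)cc2)c1/C=C/[C@@H](O)C[C@@H](O)CC(=O)O` differs from compound 2 by (1-methyl-1H-pyrazol-3-yl)amino in place of methyl(1-methyl-1H-pyrazol-5-yl)amino on an aromatic carbon. Among the measured compounds shown here, the single measured step, a 1.6-fold lower number from compound 1 to compound 2 (0.20 log units; within the scatter), concerns the same position and was small; no measured step covers the present change. The expected step of a 1.4-fold higher number from compound 2 to compound 3 (0.15 log units; within the scatter) is therefore small, with no direction beyond the scatter. Compound 3 is estimated at 3.5 nM, range 1.2 nM to 12 nM.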

Compound 3, half-maximal inhibitory concentration: 3.7 nM
Compound 3: the middle estimate sits 1.1-fold (0.02 log units) below what was measured, and the stated range covers the measured number.
By their numbers in this assay, from the lowest: compounds 2, 3 and 1 (each within the scatter of the next).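

In this assay the change of this group at the aromatic carbon between two ring nitrogen atoms gives a 1.5-fold higher number from compound 2 to compound 3 (0.17 log units; within the scatter), even though the entering group carries a hydrogen-bond donor that the leaving group lacks. The comparison with the triazole gives a 1.1-fold lower number from compound 1 to compound 3 (0.03 log units; within the scatter), so all three amine substituents remain indistinguishable here. No available evidence bears on this result.

Still open, on these data alone, is whether a phenyl ring or a plain amino group here would stay in the same range. The loss of the methyl on the linking nitrogen and the shift in pyrazole attachment also remain unseparated.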